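A non-aromatic ring in place of pyridin-3-yl

The source may hold more compounds than are shown below. What is called first, only, known or untested is meant among the compounds shown, and "the series" means these compounds.

Compound 1 `O=C(O[C@H]1C[C@H](n2cc(F)c(=O)[nH]c2=O)O[C@@H]1COP(=O)(O)Oc1cccnc1)c1ccccc1` and compound 2 `O=C(O[C@H]1C[C@H](n2cc(F)c(=O)[nH]c2=O)O[C@@H]1COP(=O)(O)Oc1ccc2ncccc2c1)c1ccccc1` share one core and differ only in the group carried on an oxygen. Among the measured compounds shown here, in a functional assay on MRC5 cells (Homo sapiens) for cytotoxicity, read by MTT assay, with a stated time of 48 h (a lower number here means a stronger inhibitor, a higher number a weaker inhibitor), compound 1 gives 15600 nM, the highest of the two numbers known so far, while compound 2 gives 1300 nM. For the measured compounds named here, the one measured step, a 12-fold lower number from compound 1 to compound 2 (1.08 log units; beyond the scatter), shows that a change at this oxygen can move the number well beyond the scatter. Compound 3 `C[N+]1(C)CCC(OP(=O)([O-])OC[C@H]2O[C@@H](n3cc(F)c(=O)[nH]c3=O)C[C@@H]2OC(=O)c2ccccc2)CC1` departs from compound 1 by a group of 12 heavy atoms (7 carbon, 1 nitrogen, 3 oxygen, 1 phosphorus; one six-membered non-aromatic ring with 1 hetero atom) in place of a group of 10 heavy atoms (5 carbon, 1 nitrogen, 3 oxygen, 1 phosphorus; one six-membered aromatic ring with 1 hetero atom), on an oxygen on a saturated carbon. Going by the values given here, no measured step bears on a non-aromatic ring entering at this position; the step from compound 1 to compound 2 only shows that the site responds, and it gives no direction for compound 3. Compound 3 is thus expected to stay close to compound 1, with a 1.0-fold lower number from compound 1 to compound 3 (0.02 log units; within the scatter). The estimate for compound 3 is 15000 nM, within 5000 nM to 50000 nM.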

Compound 3, half-maximal inhibitory concentration: 8300 nM
Compound 3: the middle estimate sits 1.8-fold (0.26 log units) above what was measured; the measured number falls inside the stated range.
By their numbers in this assay, from the lowest: compound 2; then compounds 3 and 1 (each within the scatter of the next).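

In this assay, the non-aromatic ring in place of pyridin-3-yl gives a 1.9-fold lower number from compound 1 to compound 3 (0.27 log units; within the scatter). At this place, on an oxygen on a saturated carbon, an aromatic ring is therefore not needed to keep the number within the scatter of compound 1. The site that answered quinolin-6-yl with a 12-fold lower number from compound 1 to compound 2 (1.08 log units; beyond the scatter) thus does not answer every exchange of group with a step beyond the scatter, and nothing at hand explains this difference.

The compounds shown leave open whether a cyclohexyl ring, with no nitrogen, would read like compound 3. They also leave open whether an open-chain amine on this oxygen would do the same, or whether a second ring fused to the non-aromatic ring would approach compound 2.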